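This account rests on a few compounds, and the source may have more. Where it says the series, first, only, none or still open, it means among the compounds named here.

Among the measured compounds shown here, compound 1, with the structure `COC(=O)C1=C(O)C[C@H](c2ccccn2)N(Cc2ccc(OC)cc2)[C@@H]1c1ccccn1`, is the only member of this series for which a number is available: in an ADME assay on J774.1 cells (Mus musculus) for cytotoxicity, with a stated time of 48 h (on this read-out higher numbers stand for an effect only at larger amounts of compound and lower numbers for an effect already at smaller amounts), compound 1 gives 29.9 uM. Compound 2, with the structure `COC(=O)c1c(-c2ccccn2)n(Cc2ccc(C)cc2)c(-c2ccccn2)cc1=O`, was also run in this assay, but in this assay compound 2 is recorded as "not determined" (no result reported), so compound 1 stands alone on the numbers shown, with nothing to rank it against. For the measured compounds named here, no step between two measured compounds can therefore be drawn.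

Compound 3, with the structure `C=CCN1[C@@H](c2ccccn2)CC(O)=C(C(=O)OC)[C@H]1c1ccccn1`, has not yet been measured in this assay. Its difference from compound 1 is vinyl in place of 4-methoxyphenyl on a saturated chain carbon bound to an amine nitrogen in a ring. Because only the value 29.9 uM of compound 1 is known, the size of this step can only be guessed. The change removes one aromatic ring from the group on the amine nitrogen while leaving the shared core untouched, and a step of modest size toward an effect only at larger amounts, or none beyond the scatter, is expected. The step from compound 1 to compound 3 is estimated at a 1.3-fold higher number from compound 1 to compound 3 (0.13 log units; within the scatter). For compound 3 a value of 40 uM is expected, within a range from 15 uM to 110 uM.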

Compound 3, concentration for half-maximal effect: 35 uM
The estimate for compound 3 lay 1.1-fold (0.06 log units) above the measured number; the range from low to high includes it.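

Among the compounds shown here, the exchange of 4-methoxyphenyl for vinyl, on a saturated chain carbon bound to an amine nitrogen in a ring, gives the first reading at this position: in this assay it yields a 1.2-fold higher number from compound 1 to compound 3 (0.07 log units; within the scatter) and so does not move the number beyond the usual scatter. For these two compounds alone, the change from 4-methoxybenzyl to allyl removes a six-membered aromatic ring of carbon and a hydrogen-bond acceptor without a difference that can be told from repeated measurement. No measurement bears on what lies behind this result.

From the compounds shown here alone, it remains open whether the same flat reading would hold for a group of a different kind at this place, such as a carboxylic acid or an amine at the end of a longer chain. For the compounds shown here, with only one step that can be read, it is also open whether the shared core would tolerate this exchange in the same way once another part of it carries a different group.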